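The source may hold more compounds than are shown below. What is called first, only, known or untested is meant among the compounds shown, and "the series" means these compounds.

Measured so far:
- compound 1, `COC(=O)[C@H]1c2cc(/C=C/C(=O)NCCCCNC(=N)N)ccc2O[C@@H]1c1ccc(O)cc1`: in a functional assay on Caudal artery for antagonist activity at Alpha-1A adrenergic receptor (Rattus norvegicus) (on this read-out higher numbers stand for weaker inhibition and lower numbers for stronger inhibition), compound 1 gives 42200000 nM
- compound 2, `N=C(N)NCCCCNC(=O)/C=C/c1ccc2c(c1)[C@@H](C(=O)NCCCCNC(=N)N)[C@@H](c1ccc(O)cc1)O2`: in this assay compound 2 gives 17700000 nM

Compound 2 stands at the lowest of the two numbers in this assay; its nearest neighbour is compound 1, whose number is higher by a gap that lies beyond the usual scatter. Both numbers are very high, so the inhibition seen for either compound is weak.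

Compound 3, `N=C(N)NCCCCNC(=O)/C=C/c1ccc2c(c1)[C@H](C(=O)NCCCCNC(=N)N)[C@H](c1ccc(O)cc1)O2`, is not yet measured. It differs from compound 2 in this way: the two compounds have the same atoms and bonds; at least one stereo element is drawn with a configuration in one of them and without one in the other: 2 of 5 stereo elements differ; a stereocentre at a saturated ring carbon is drawn R in compound 2 and S in compound 3; a stereocentre at a saturated ring carbon is drawn S in compound 2 and R in compound 3. The atoms and bonds are unchanged; only the drawn configuration at the two ring stereocentres is inverted. For the measured compounds named here, no pair of measured compounds shows what such an inversion does in this assay, so the direction of the step is unknown. With no shown step to lean on, the expected number for compound 3 is taken close to that of compound 2, with a wide range to cover a change in either direction, giving an expected step of a 1.4-fold higher number from compound 2 to compound 3 (0.15 log units; within the scatter). The estimate for compound 3 in this assay is 25000000 nM, with a range from 5000000 nM to 120000000 nM.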

Compound 3, half-maximal inhibitory concentration: 4900000 nM
Estimate against measurement, compound 3: 5.1-fold (0.71 log units) above; the whole stated range lies above it.
By their numbers in this assay, from the lowest: compound 3; then compound 2; then compound 1.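

With the atoms and bonds unchanged, inverting the two ring stereocentres alone moves the number in this assay: a 3.6-fold lower number from compound 2 to compound 3 (0.56 log units; beyond the scatter). For the compounds shown here, this is the first step that reads on configuration, and it shows that the drawn arrangement at these ring carbons matters here, with the inverted form on the side of stronger inhibition, although compound 3 still gives a very high number at 4900000 nM, so inhibition remains weak. The only structural basis on record for this step is: the fact that one of compounds 2 and 3 is drawn with a defined configuration and the other without, at the place where they differ.

Both ring stereocentres change together in this pair. The data do not show how much of the step goes with each one, or whether a form inverted at only one of them would follow the same direction. From the compounds shown here alone, it also stays open whether the same inversion moves the number by a similar size when the ring carbon carries a carboxylic acid or the methyl ester of compound 1 instead of the guanidine-ending amide chain of compound 2, or when that chain gives way to a longer chain ending in an amine.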